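A Smaller Aryl Group on the Amine Nitrogen

The source may hold more compounds than are shown below. What is called first, only, known or untested is meant among the compounds shown, and "the series" means these compounds.

Of the compounds shown here, three built on one shared core have been tested in a functional assay on HT-29 cells (Homo sapiens) for cytotoxicity, read by sulforhodamine B assay; on this read-out higher numbers stand for weaker inhibition and lower numbers for stronger inhibition. Compound 1 `C=C1[C@@H](OC(C)=O)C[C@@H]2[C@](C)(CO[Si](C)(C)C(C)(C)C)[C@H](OC(C)=O)CC[C@@]2(C)[C@@H]1C[C@@H](Nc1ccccc1F)C1=CCOC1=O` gives 3710 nM, compound 2 `C=C1[C@@H](OC(C)=O)C[C@@H]2[C@](C)(CO[Si](C)(C)C(C)(C)C)[C@H](OC(C)=O)CC[C@@]2(C)[C@@H]1C[C@@H](Nc1ccc(OC)cc1)C1=CCOC1=O` gives 5370 nM, and compound 3 `C=C1[C@@H](OC(C)=O)C[C@@H]2[C@](C)(CO[Si](C)(C)C(C)(C)C)[C@H](OC(C)=O)CC[C@@]2(C)[C@@H]1C[C@@H](Nc1cccc2ccccc12)C1=CCOC1=O` gives 15000 nM. Compound 3 thus stands highest of the three: a 4.0-fold higher number from compound 1 to compound 3 (0.61 log units; beyond the scatter) and a 2.8-fold higher number from compound 2 to compound 3 (0.45 log units; beyond the scatter), both beyond the scatter, whereas a 1.4-fold higher number from compound 1 to compound 2 (0.16 log units; within the scatter).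

Compound 4 `C=C1[C@@H](OC(C)=O)C[C@@H]2[C@](C)(CO[Si](C)(C)C(C)(C)C)[C@H](OC(C)=O)CC[C@@]2(C)[C@@H]1C[C@@H](Nc1cccc(OC)c1)C1=CCOC1=O` differs from compound 3 in one place: 3-methoxyphenyl in place of naphthalen-1-yl on an amine nitrogen. The two steps that bear on this are those leading into compound 3, in which naphthalen-1-yl in place of one six-membered aromatic ring of carbon only raised the number; here the change runs the other way, toward a group resembling the 4-methoxyphenyl of compound 2. The number for compound 4 in this assay is therefore expected to fall, by roughly the reverse of the step from compound 2 to compound 3, as an expected step of a 3.0-fold lower number from compound 3 to compound 4 (0.48 log units; beyond the scatter). Compound 4 is estimated at 5000 nM, with a range from 2500 nM to 10000 nM.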

Compound 4, half-maximal inhibitory concentration: > 50000 nM
Compound 4 gave a limit, no number (the forecaster's own chance of this, stated with the estimate: 5%); at least 10-fold (1.00 log units) between middle value and limit.
By their numbers in this assay, from the lowest: compounds 1 and 2 (each within the scatter of the next); then compound 3. At a limit, above all of these: compound 4.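

Compound 4 gives a limit and no number in this assay: the limit of > 50000 nM in this assay, at which 1 of the 4 values shown sits.

Read against compound 2, the change from 4-methoxyphenyl to 3-methoxyphenyl on the amine nitrogen is an at least 9.3-fold higher number from compound 2 to compound 4 (0.96 log units; beyond the scatter), so this position separates two groups with the same name apart from where the methoxy stands, something the earlier compounds could not show. Having one six-membered aromatic ring in place of two is also no assurance of a lower number here, since the change from naphthalen-1-yl is an at least 3.3-fold higher number from compound 3 to compound 4 (0.52 log units; beyond the scatter), and the change from 2-fluorophenyl is an at least 13-fold higher number from compound 1 to compound 4 (1.12 log units; beyond the scatter).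

The limit leaves the true size of all three steps open. Also open, as far as these compounds go, is whether the rise follows the methoxy group itself or any group there, as 3-fluorophenyl or 3-hydroxyphenyl on the same amine nitrogen would test.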